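Thiophene in Place of Methoxyphenyl at the Ring Carbon

The source may report more compounds than this note shows. Statements on the series, on what has been measured and on what is new or still open speak of the compounds shown alone.

For the measured compounds named here, compound 2 `COc1ccccc1C1C(C#N)=C(N)N(c2cc(OC)c(OC)c(OC)c2)C2=C1C(=O)CC(C)(C)C2` is one of three compounds so far measured in a functional assay on Ehrlich cells (Mus musculus) for cytotoxicity (a higher number here means a weaker inhibitor, a lower number a stronger inhibitor), where compound 2 gives 26600 nM. Compound 3 `COc1cc(N2C(N)=C(C#N)C(c3ccc([N+](=O)[O-])cc3)C3=C2CC(C)(C)CC3=O)cc(OC)c1OC` gives 25000 nM in this assay, and compound 1 `COc1cc(N2C(N)=C(C#N)C(c3c(O)ccc4ccccc34)C3=C2CC(C)(C)CC3=O)cc(OC)c1OC` gives 143000 nM. On these numbers compound 2 stands second highest of the three: the step of a 1.1-fold lower number from compound 2 to compound 3 (0.03 log units; within the scatter) is within the scatter, while the step of a 5.4-fold lower number from compound 1 to compound 2 (0.73 log units; beyond the scatter) lies beyond it, as does the step of a 5.7-fold lower number from compound 1 to compound 3 (0.76 log units; beyond the scatter). Compound 4 `COc1cc(N2C(N)=C(C#N)C(c3cccs3)C3=C2CC(C)(C)CC3=O)cc(OC)c1OC` has not yet been measured. It differs from compound 2 in one place: thiophen-2-yl in place of 2-methoxyphenyl on a saturated ring carbon. All three measured steps concern groups on this same saturated ring carbon, and only the loss of 2-hydroxynaphthalen-1-yl moved the number. Because the step of a 1.1-fold lower number from compound 2 to compound 3 (0.03 log units; within the scatter) stayed within the scatter for an exchange of one aromatic group for another at this carbon, the step of a 1.0-fold higher number from compound 2 to compound 4 (0.01 log units; within the scatter) is expected to stay within the scatter as well. Compound 4 is therefore estimated at 27000 nM, with a range from 9000 nM to 80000 nM.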

Compound 4, half-maximal inhibitory concentration: "not active" (no number reported)
Compound 4: no number reported; no gap can be computed for the estimate.
By their numbers in this assay, from the lowest: compounds 3 and 2 (each within the scatter of the next); then compound 1.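

For the compounds shown here, compound 4 is reported in this assay only as not active, without a number, and no step from compound 2 to compound 4 can be read. The compounds shown leave open how far thiophen-2-yl on this saturated ring carbon separates compound 4 from compound 2. Nothing shown here accounts for this result.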